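Aryl exchange from compound 3 to compound 4

The source may report more compounds than this note shows. Statements on the series, on what has been measured and on what is new or still open speak of the compounds shown alone.

- compound 1 `OC[C@H]1O[C@@H](n2cnc3c(NCc4ccc(Br)cc4)ncnc32)[C@H](O)[C@@H]1O`: 47400 nM
- compound 2 `Cc1cccc(CNc2ncnc3c2ncn3[C@@H]2O[C@H](CO)[C@@H](O)[C@H]2O)c1`: 6400 nM
- compound 3 `COc1cc(CNc2ncnc3c2ncn3[C@@H]2O[C@H](CO)[C@@H](O)[C@H]2O)cc(OC)c1`: 20200 nM

All three values come from a functional assay on HL-60 cells (Homo sapiens) for antiproliferative activity, with a stated time of 72 h; a lower number here means a stronger inhibitor, a higher number a weaker inhibitor. Compound 3, at 20200 nM, holds the middle of the three numbers. Compound 4 `OC[C@H]1O[C@@H](n2cnc3c(NCc4ccc(F)cc4F)ncnc32)[C@H](O)[C@@H]1O` differs from it as follows: 2,4-difluorophenyl in place of 3,5-dimethoxyphenyl on a saturated chain carbon bound to a nitrogen on an aromatic ring. The exchanges at this same place bear on the change: a 7.4-fold lower number from compound 1 to compound 2 (0.87 log units; beyond the scatter), a 2.3-fold lower number from compound 1 to compound 3 (0.37 log units; beyond the scatter) and a 3.2-fold higher number from compound 2 to compound 3 (0.50 log units; beyond the scatter), each modest but beyond the scatter. None of them involves 2,4-difluorophenyl. For the measured compounds named here, the only halogen-carrying group so far is on compound 1, at 47400 nM, the highest number, so a slight lean upward is expected at most. The expected step stays within the scatter: a 1.2-fold higher number from compound 3 to compound 4 (0.09 log units; within the scatter). The estimate for compound 4 is 25000 nM, with an expected range of 8000 nM to 60000 nM.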

Compound 4, half-maximal inhibitory concentration: 3400 nM
Compound 4: the middle estimate sits 7.4-fold (0.87 log units) above what was measured, outside the stated range (below it).
By their numbers in this assay, from the lowest: compounds 4 and 2 (each within the scatter of the next); then compound 3; then compound 1.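

In this assay, a halogen on the aryl group does not by itself go with a high number at this position: compound 1 carries bromine and has the highest number, yet 2,4-difluorophenyl gives a 5.9-fold lower number from compound 3 to compound 4 (0.77 log units; beyond the scatter) and a 14-fold lower number from compound 1 to compound 4 (1.14 log units; beyond the scatter) and the second of these is large. The exchange for 3-methylphenyl gives a 1.9-fold lower number from compound 2 to compound 4 (0.27 log units; within the scatter) and leaves compound 2 and compound 4 unordered. No measured evidence on the cause of these steps is at hand.

From the compounds shown here alone, whether 4-fluorophenyl or 2-fluorophenyl alone would match 2,4-difluorophenyl stays open. So does the effect of an amine or carboxylic acid on the aryl ring, or of a longer chain to it.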